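Fused-ring amide variants on the shared piperazine urea core

A few compounds are considered here, and "the series" means these few. Any claim that something is new, unique, unknown or untested is made for them only; others in the source may bear on it.

Compound 1 `O=C(Nc1cccc2nonc12)N1CCN(Cc2cccc(Oc3ccc(Cl)cc3)c2)CC1`: 28 nM
Compound 2 `O=C(Nc1cccc2cn[nH]c12)N1CCN(Cc2cccc(Oc3ccc(Cl)cc3)c2)CC1`: 1300 nM
Compound 3 `O=C(Nc1noc2ccccc12)N1CCN(Cc2cccc(Oc3ccc(Cl)cc3)c2)CC1`: 10 nM

In an assay on isolated protein for inhibition of Fatty-acid amide hydrolase 1 (Homo sapiens), with a stated time of 60 min (on this read-out higher numbers stand for weaker inhibition and lower numbers for stronger inhibition), compound 3 gives the lowest number of the three: the step of a 2.8-fold lower number from compound 1 to compound 3 (0.45 log units; beyond the scatter) is modest, and the step of a 130-fold lower number from compound 2 to compound 3 (2.11 log units; beyond the scatter) is large. Compound 4 `O=C(Nc1noc2ccncc12)N1CCN(Cc2cccc(Oc3ccc(Cl)cc3)c2)CC1` differs from compound 3 by a group of 9 heavy atoms (6 carbon, 2 nitrogen, 1 oxygen; one five-membered aromatic ring with 2 hetero atoms, one six-membered aromatic ring with 1 hetero atom) in place of a group of 9 heavy atoms (7 carbon, 1 nitrogen, 1 oxygen; one five-membered aromatic ring with 2 hetero atoms, one six-membered aromatic ring of carbon only), on an amide-type nitrogen. Within the data shown here, none of the measured steps changes the six-membered aromatic ring; a 46-fold higher number from compound 1 to compound 2 (1.67 log units; beyond the scatter) and the two other steps all alter the five-membered aromatic ring of the group on the amide-type nitrogen. Among the measured compounds shown here, no measured step therefore bears directly on this change, and for compound 4 a step of a 1.5-fold higher number from compound 3 to compound 4 (0.18 log units; within the scatter) is expected, within the scatter. Compound 4 is estimated at 15 nM, with a range from 4 nM to 60 nM.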

Compound 4, half-maximal inhibitory concentration: 180 nM
Estimate against measurement, compound 4: 12-fold (1.08 log units) below; the whole stated range lies below it.
By their numbers in this assay, from the lowest: compound 3; then compound 1; then compound 4; then compound 2.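

In this assay, the six-membered aromatic ring of the group on the amide-type nitrogen proves to matter as much as the five-membered one: a six-membered aromatic ring with 1 hetero atom in place of one of carbon only gives an 18-fold higher number from compound 3 to compound 4 (1.26 log units; beyond the scatter), a large step. The new group lands mid-series, with modest steps in opposite directions: a 6.4-fold higher number from compound 1 to compound 4 (0.81 log units; beyond the scatter) and a 7.2-fold lower number from compound 2 to compound 4 (0.86 log units; beyond the scatter). No evidence on the origin of the large step is at hand.

The compounds shown leave open how a fluorine or a methoxy group on that six-membered ring would read. As far as these compounds go, whether the ring nitrogen placed elsewhere in that ring would give a step of the same size also stays open.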